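The source may hold more compounds than are shown below. What is called first, only, known or untested is meant among the compounds shown, and "the series" means these compounds.

- compound 1 (`O=S1(=O)C=C(Sc2nnc(-c3cccnc3)o2)c2ccccc21`) gives 4000 nM
- compound 2 (`Nc1ccc(-c2nnc(SC3=CS(=O)(=O)c4ccccc43)o2)cc1`) gives 4000 nM
- compound 3 (`COc1ccc(-c2nnc(SC3=CS(=O)(=O)c4ccccc43)o2)cc1`) gives 2000 nM

These numbers come from an ADME assay on HEK293 cells (Homo sapiens) for cytotoxicity, read by fluorescence and resazurin assay, with a stated time of 24 h; a lower number here means that less compound is tolerated, a higher number that more compound is tolerated. In it, compound 3 at 2000 nM stands within the scatter of both other compounds, so the three cannot be ranked. Compound 4 (`O=S1(=O)C=C(Sc2nnc(-c3ccccn3)o2)c2ccccc21`) keeps the shared core but carries pyridin-2-yl in place of 4-methoxyphenyl on an aromatic carbon. Among the measured compounds shown here, the nearest precedent is the exchange of pyridin-3-yl for 4-methoxyphenyl, which is the reverse kind of swap and gave a 2.0-fold lower number from compound 1 to compound 3 (0.30 log units; within the scatter). The other two steps, no change at the digits printed from compound 1 to compound 2 (within the scatter) and a 2.0-fold lower number from compound 2 to compound 3 (0.30 log units; within the scatter), also stayed within the scatter. Across these few compounds, then, changing this aromatic group has not moved the number measurably. For the measured compounds named here, no measured compound carries pyridin-2-yl, so the range must stay fairly wide. The expected result is no shift beyond the scatter, with an estimated step of a 1.5-fold higher number from compound 3 to compound 4 (0.18 log units; within the scatter). For compound 4 the estimated value is 3000 nM, with an expected range from 1300 nM to 7500 nM.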

Compound 4, half-maximal cytotoxic concentration: 5000 nM
The estimate for compound 4 lay 1.7-fold (0.22 log units) below the measured number; the measured number falls inside the stated range.
By their numbers in this assay, from the lowest: compounds 3, 1, 2 and 4 (each within the scatter of the next, the first and the last beyond it).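

In this assay, among the compounds shown here, exchanging 4-methoxyphenyl for pyridin-2-yl gives a 2.5-fold higher number from compound 3 to compound 4 (0.40 log units; beyond the scatter), the first step in this set beyond the usual scatter, so the group at this position can shift the tolerated concentration, though only modestly. The effect is limited: pyridin-2-yl in place of 4-aminophenyl gives a 1.3-fold higher number from compound 2 to compound 4 (0.10 log units; within the scatter), and pyridin-2-yl in place of pyridin-3-yl gives a 1.3-fold higher number from compound 1 to compound 4 (0.10 log units; within the scatter), both within the scatter, so neither exchange can be told apart from no change. For the compounds shown here, no evidence here explains why the one exchange stands out.

On these data alone, it remains open whether a group of another kind on this aromatic carbon, such as a carboxylic acid or a saturated amine like morpholine, would move the number further. A single modest step also cannot show whether that range extends beyond these four compounds.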